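Trimming a Cyclopentyl to Methyl on a Bicyclic Core

This account rests on a few compounds, and the source may have more. Where it says the series, first, only, none or still open, it means among the compounds named here.

Compound 1 `COc1cc(-c2cnn3cc(OC)c(C4CCCC4)nc23)ccn1` was tested in an assay on isolated protein for inhibition of activin receptor type-2A (Homo sapiens), read by 33P incorporation, with a stated time of 20 min, in the presence of a further agent that is not named here (on this read-out higher numbers stand for weaker inhibition and lower numbers for stronger inhibition), where compound 1 gives 2900 nM. Two companions set the scale. Compound 3 `Cn1cc(-c2nc3c(-c4ccnc(OC5CC5)c4)cnn3cc2OCCCC(C)(C)O)cn1` gives 2900 nM, level with compound 1 at the digits shown, so the two sit together at the high end of the three numbers. Compound 2 `Cc1ccc(-c2cnc(N)c(C(=O)NC3CCCCC3)n2)cc1` gives 180 nM, a lower number than compound 1 by a margin that lies well beyond the usual scatter of repeated measurements.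

Compound 4 `COc1cc(-c2cnn3cc(OC)c(C)nc23)ccn1` has not yet been measured. It differs from compound 1 in one place: methyl in place of cyclopentyl on an aromatic carbon. Among the measured compounds shown here, no pair of measured compounds shows the effect of this change, so the direction rests on expectation alone. Swapping cyclopentyl for methyl on the shared core is expected to weaken inhibition only slightly, and the step of a 1.7-fold higher number from compound 1 to compound 4 (0.24 log units; within the scatter) is estimated to be modest, close to the edge of the scatter. Compound 4 is therefore expected to give about 5000 nM, within a range from 1500 nM to 20000 nM.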

Compound 4, half-maximal inhibitory concentration: 1200 nM
Compound 4: middle estimate off by 4.2-fold (0.62 log units), on the high side; measured number below the stated range.
By their numbers in this assay, from the lowest: compound 2; then compound 4; then compounds 1 and 3 (each within the scatter of the next).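

Cutting the group down does not cost inhibition at this position: in this assay, methyl in place of cyclopentyl gives a 2.4-fold lower number from compound 1 to compound 4 (0.38 log units; beyond the scatter), a modest step toward stronger inhibition. The five-membered carbon ring is therefore not needed on this aromatic carbon for the inhibition seen with the shared core, and the single carbon of the methyl does better. No measurement at hand explains why the smaller group gives the lower number.

Among the compounds shown here, with only this one step at the position, it remains open whether the trend continues with a bare hydrogen. On these data alone, it also remains open whether the trend reverses with an intermediate group such as ethyl. As far as these compounds go, how an amine, a carboxylic acid or a longer chain would fare on this same carbon also remains open.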